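This account rests on a few compounds, and the source may have more. Where it says the series, first, only, none or still open, it means among the compounds named here.

Two compounds have so far been measured in a functional assay on Ehrlich cells (Mus musculus) for cytotoxicity, read by trypan blue exclusion, with a stated time of 2 h, tested at 10 ug/mL; a higher number here means a stronger effect of the compound at the concentration tested, a lower number a weaker effect:

Compound 1 `N#CC1=C(N)N(c2ccc(S(N)(=O)=O)cc2)C2=C(CCCC2)C1c1ccccc1` gives 5%.
Compound 2 `N#CC1=C(N)N(c2ccc(S(N)(=O)=O)cc2)C2=C(CCCC2)C1c1ccc(O)cc1` gives 20%.

Of these two numbers, compound 1 stands lowest. Its nearest neighbour is compound 2, reached by a number 15 percentage points higher from compound 1 to compound 2 (beyond the scatter), the step that goes with hydroxy in place of hydrogen on an aromatic carbon. Among the compounds with values here, that is the only measured step available.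

Compound 3 `N#CC1=C(N)N(c2ccc(S(N)(=O)=O)cc2)C2=C(CCCC2)C1c1cccs1` differs from compound 1 by thiophen-2-yl in place of phenyl on a saturated ring carbon. Within the data shown here, the single measured step concerns a group added to the phenyl ring while that ring stays in place; it says nothing about exchanging the ring itself for thiophen-2-yl. So no measured step bears on the change from compound 1 to compound 3, and there is no ground for expecting a move in either direction beyond the scatter. The expected step is therefore a number 3 percentage points higher from compound 1 to compound 3 (within the scatter), that is, no change beyond the scatter. Compound 3 is estimated at 8% in this assay, with a range from 0% to 25%.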

Compound 3, a percentage reported as activity, at one concentration (the size of the read-out at that concentration, not a potency): 0%
Beside the measured number, compound 3's estimate is 8 percentage points above it, within the range that was stated.
By their numbers in this assay, from the lowest: compounds 3 and 1 (each within the scatter of the next); then compound 2.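

On the saturated ring carbon of the shared core, thiophen-2-yl takes the place of phenyl with no readable change in this assay, the result being a number 5 percentage points lower from compound 1 to compound 3 (within the scatter). Exchanging the whole ring, a six-membered ring of carbon only for a five-membered ring with one sulfur, therefore does not raise the read-out at this carbon, whereas the comparison with the hydroxy-bearing compound gives a number 20 percentage points lower from compound 2 to compound 3 (beyond the scatter), so that among these three compounds only compound 2 stands beyond the scatter of the other two. No measured evidence is available to explain these numbers.

Going by these compounds, it remains open whether a hydroxy group on the thiophen-2-yl ring would give a step like the one seen on phenyl, since that step is known for the phenyl ring alone. Also open, on these data alone, is how a methoxy group or an amine on the phenyl ring, or a pyridine ring in its place, would read at this carbon in this assay.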